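Swapping Chloro for Cyano in Compound 3

A few compounds are considered here, and "the series" means these few. Any claim that something is new, unique, unknown or untested is made for them only; others in the source may bear on it.

Compound 3 `O=C(Nc1ccc(S(=O)(=O)Nc2ccccc2)cc1)c1ccc(Cl)cc1F` gives 3980 nM in a functional assay on HEK293 cells for agonist activity at probable G-protein coupled receptor 27 (Homo sapiens), read by a luciferase reporter and beta-arrestin recruitment, with a stated time of 10 min; a higher number here means that more compound is needed for the effect, a lower number that less compound is needed. Among the two compounds that return a number, compound 3 stands highest; its nearest neighbour is compound 1 `O=C(Nc1ccc(S(=O)(=O)Nc2ccccc2Cl)cc1)c1ccc(Cl)cc1Cl`, which in this assay gives 1260 nM. Compound 2 `O=C(NS(=O)(=O)c1ccc(NC(=O)c2ccc(Cl)cc2Cl)cc1)c1ccccc1` reaches only a limit of the assay, in this assay reported as > 100000 nM. Among the compounds with values here, the single step measured between compounds that differ in one place is an at least 79-fold higher number from compound 1 to compound 2 (1.89 log units; beyond the scatter), a large change on the sulfonamide nitrogen; one of the three values sits at the limit of > 100000 nM in this assay, at which 1 of the 3 values shown sits.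

Compound 4 `N#Cc1ccc(C(=O)Nc2ccc(S(=O)(=O)Nc3ccccc3)cc2)c(F)c1` differs from compound 3 by cyano in place of chloro on an aromatic carbon. Within the data shown here, this change sits at the far end of the shared core from the sulfonamide nitrogen where the one measured step was taken, so that step does not bear on it, and compound 1 and compound 3 differ from each other in more than one place, so their two values give no single step either. Among the measured compounds shown here, with no measured step carrying the change, the number for compound 4 is expected to stay close to that of compound 3, and compound 4 is estimated at 5000 nM, within a range from 1500 nM to 16000 nM. The step this estimate means, a 1.3-fold higher number from compound 3 to compound 4 (0.10 log units; within the scatter), is expected to lie within the usual scatter.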

Compound 4, half-maximal effective concentration: 229 nM
The estimate for compound 4 lay 22-fold (1.34 log units) above the measured number; the measured number lies below the stated range.
By their numbers in this assay, from the lowest: compound 4; then compound 1; then compound 3. At a limit, above all of these: compound 2.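

In this assay, the aromatic carbon para to a large group proves to be a place where one change moves the number strongly: going from 4-chloro-2-fluorophenyl to 4-cyano-2-fluorophenyl, cyano in place of chloro gives a 17-fold lower number from compound 3 to compound 4 (1.24 log units; beyond the scatter), a large step. The only earlier step between compounds differing in one place, an at least 79-fold higher number from compound 1 to compound 2 (1.89 log units; beyond the scatter), was taken on the sulfonamide nitrogen and ran the other way, so this is the first single change shown that lowers the number, and it does so at the far end of the shared core. Within the data shown here, nothing measured so far offers an explanation for the size of this step.

Going by these compounds, it stays open whether the lower number is particular to cyano at this carbon, or whether an amine, a carboxylic acid or a methyl ester in the same place would also move it. On these data alone, it is equally open whether cyano in place of chloro would give a step of similar size with the 2-chlorophenyl group of compound 1 on the sulfonamide nitrogen, or without the fluoro group on the same ring.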